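A few compounds are considered here, and "the series" means these few. Any claim that something is new, unique, unknown or untested is made for them only; others in the source may bear on it.

Working notes on the series. Compound 1 `Cc1cc(C)c(NC(=O)N(Cc2cc(-c3ccccc3)on2)C2CCCCCC2)c(C)c1` and compound 2 `Cc1cc(C)c(NC(=O)N(Cc2cccc(-c3nnnn3C)c2)C2CCCCCC2)c(C)c1` share one core; compound 3 `CSc1cc(C)nc(SC)c1NC(=O)N(Cc1ccccc1)Cc1cccc(-c2ccn(C)n2)c1` carries a different core. In a functional assay on a cell-free system (plasma) with sterol O-acyltransferase, Soat (Rattus norvegicus) as the target (a lower number here means that less compound is needed, a higher number that more compound is needed for the effect), compound 1 gives > 1 mg/kg, which is a limit and not a number. In this assay compound 2 gives > 1 mg/kg, again a limit and not a number. Compound 3 gives < 1 mg/kg in this assay, also a limit. Going by the values given here, compound 2 therefore stands at the limit of > 1 mg/kg in this assay, at which 2 of the 3 values shown sit, and only the limit of < 1 mg/kg in this assay, at which 1 of the 3 values shown sits, sits elsewhere among the three values; no measured step between any two of them can be drawn, and there is no step that shows what the change below does.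

Compound 4 `Cc1cc(C)c(NC(=O)N(Cc2cccc(-c3ccnn3C)c2)C2CCCCCC2)c(C)c1` differs from compound 2 by 1-methyl-1H-pyrazol-5-yl in place of 1-methyl-1H-tetrazol-5-yl on an aromatic carbon. With nothing measured on this change, no step beyond the usual scatter is expected in either direction. For compound 4 the estimate in this assay is 1.5 mg/kg (range 0.4 mg/kg to 5 mg/kg), so the expected step is a step that the limit leaves unreadable from compound 2 to compound 4, and a further limit is quite likely.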

Compound 4, dose for half-maximal effect: > 1 mg/kg
Compound 4: a limit, no number (the forecaster's own chance of this, stated with the estimate: 60%); the middle value lies beyond the limit too.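

In this assay compound 4 gives > 1 mg/kg, a limit and not a number. Going by these compounds alone, compound 2 gives > 1 mg/kg, also a limit, so no step from compound 2 to compound 4 can be read. Still open, from the compounds shown here alone, is how far 1-methyl-1H-pyrazol-5-yl in place of 1-methyl-1H-tetrazol-5-yl shifts the dose for half-maximal effect, if at all.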